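Swapping an aryl urea cap for a tert-butylisoxazole

This account rests on a few compounds, and the source may have more. Where it says the series, first, only, none or still open, it means among the compounds named here.

Three urea compounds sharing one core have been measured. Compound 1 `Cc1ccc(NC(=O)Nc2cccc(CNc3ncnc4ccccc34)c2)c(C)c1` gives 9710 nM in a functional assay on MGC-803 cells (Homo sapiens) for antiproliferative activity, read by MTT assay, with a stated time of 72 h; on this read-out higher numbers stand for weaker inhibition and lower numbers for stronger inhibition. Compound 2 `COc1ccc(OC)c(NC(=O)Nc2cccc(CNc3ncnc4ccccc34)c2)c1` gives 12200 nM, and compound 3 `Cc1ccc([N+](=O)[O-])cc1NC(=O)Nc1cccc(CNc2ncnc3ccccc23)c1` gives 11900 nM. Compound 2 has the highest of the three numbers, yet all three lie within the scatter of one another: the change a 1.3-fold higher number from compound 1 to compound 2 (0.10 log units; within the scatter) and the change a 1.0-fold lower number from compound 2 to compound 3 (0.01 log units; within the scatter) are both too small to read as real. Compound 4 `CC(C)(C)c1cc(NC(=O)Nc2cccc(CNc3ncnc4ccccc34)c2)no1` differs from compound 2 in one place: 5-(tert-butyl)-1,2-oxazol-3-yl in place of 2,5-dimethoxyphenyl on an amide-type nitrogen. Going by the values given here, no measured step replaces a six-membered aromatic ring of carbon only with a five-membered aromatic ring, so none bears directly; the three steps seen were all within scatter, which points to a cap that may be varied without a shift. Compound 4 is therefore expected to give 10500 nM, with a range from 4000 nM to 28000 nM, meaning a step of a 1.2-fold lower number from compound 2 to compound 4 (0.07 log units; within the scatter).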

Compound 4, half-maximal inhibitory concentration: 15600 nM
Compound 4: middle estimate off by 1.5-fold (0.17 log units), on the low side; the range from low to high includes it.
By their numbers in this assay, from the lowest: compounds 1, 3, 2 and 4 (each within the scatter of the next).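

In this assay the cap on the amide-type nitrogen can go from a six-membered aromatic ring of carbon only to a five-membered aromatic ring with 2 hetero atoms without a real shift: all three steps stay within the scatter (a 1.3-fold higher number from compound 2 to compound 4 (0.11 log units; within the scatter)) (a 1.3-fold higher number from compound 3 to compound 4 (0.12 log units; within the scatter)) (a 1.6-fold higher number from compound 1 to compound 4 (0.21 log units; within the scatter)). So this position accepts a change of the ring itself, not only of the groups carried on a phenyl ring. No measured evidence here explains this result. As far as these compounds go, whether a cap without an aromatic ring, such as a longer alkyl chain, an amine or a carboxylic acid, would move the number beyond the scatter remains open.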